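The source may report more compounds than this note shows. Statements on the series, on what has been measured and on what is new or still open speak of the compounds shown alone.

Among the measured compounds shown here, in a functional assay on Ishikawa cells (Homo sapiens) for antiproliferative activity, read by MTT assay, with a stated time of 48 h (on this read-out lower numbers stand for stronger inhibition and higher numbers for weaker inhibition), compound 1 (`CCN(CC)CC(=O)Nc1ccc(Nc2cc(Cl)nc(-c3ccc(OC)cc3)n2)cc1`) gives 5810 nM, the lower of the two numbers measured so far, and compound 2 (`COc1ccc(-c2nc(Cl)cc(Nc3ccc(NC(=O)CN4CCCC4)cc3)n2)cc1`) gives 18400 nM. Compound 3 (`CCN(CC)CC(=O)Nc1ccc(Nc2nc(-c3ccc(OC)cc3)nc(Cl)c2-c2ccccc2)cc1`) keeps the diethylamino side chain of compound 1 and changes the core at one place: phenyl in place of hydrogen on an aromatic carbon. This puts phenyl in place of hydrogen on an aromatic carbon, ortho to a chloro group.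

For the measured compounds named here, only one measured step is available, a 3.2-fold higher number from compound 1 to compound 2 (0.50 log units; beyond the scatter), which is modest. It replaces diethylamino with pyrrolidin-1-yl on the side chain, so it bears only loosely on the new change and serves as a rough guide to step size in this assay. Going by the values given here, no measured compound carries any substituent on this aromatic carbon, so the data give no direction. The best expectation is therefore no step beyond the scatter, with a wide margin on both sides. The estimate corresponds to an expected 1.2-fold lower number from compound 1 to compound 3 (0.07 log units; within the scatter). For compound 3 the expected value is 5000 nM, with an estimated range from 1500 nM to 18000 nM.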

Compound 3, half-maximal inhibitory concentration: > 40000 nM
Compound 3: only a limit was reported; the forecaster's own chance of this, stated with the estimate: 10%; middle value at least 8.0-fold (0.90 log units) away from the limit.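

Working note on the aromatic carbon ortho to a chloro group: in this assay compound 3 gives > 40000 nM, which is a limit of the assay and not a number: the limit of > 40000 nM in this assay, at which 1 of the 3 values shown sits. Phenyl in place of hydrogen at this carbon gives an at least 6.8-fold higher number from compound 1 to compound 3 (0.83 log units; beyond the scatter), so the true size of the step stays open on the high side, but its direction is fixed as weaker inhibition. Compounds 1 and 2 both carry hydrogen here and differ only in the side chain, with a 3.2-fold higher number from compound 1 to compound 2 (0.50 log units; beyond the scatter), so they said nothing about this position; compound 3 now shows that, on the core of compound 1, this carbon does not accept a phenyl group without a loss beyond the scatter.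

With phenyl as the only group shown at this carbon, it remains open whether a smaller group, such as methyl or fluoro, or a polar one, such as an amine or a carboxylic acid, would stay close to compound 1 at 5810 nM. As far as these compounds go, it also remains open whether phenyl at this carbon would have the same effect alongside the pyrrolidin-1-yl side chain of compound 2.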